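A furan for phenyl swap in a growth-inhibition series

A few compounds are considered here, and "the series" means these few. Any claim that something is new, unique, unknown or untested is made for them only; others in the source may bear on it.

Measured compounds:
Compound 1 `COc1cc(/C=C/C(=O)/C=C/c2ccccc2)ccc1OCc1cn(CCCOc2cc(=O)oc3ccccc23)nn1` — "not active" (no number reported)
Compound 2 `COc1cc(/C=C/C(=O)/C=C/c2cc(OC)c(OC)c(OC)c2)ccc1OCc1cn(CCOc2cc(=O)oc3ccccc23)nn1` — 22%
Compound 3 `COc1ccccc1/C=C/C(=O)/C=C/c1ccc(OCc2cn(CCCCCOc3cc(=O)oc4ccccc34)nn2)c(OC)c1` — "not active" (no number reported)

In a functional assay on PC-3 cells (Homo sapiens) for inhibition, read by sulforhodamine B assay, with a stated time of 48 h, tested at 50 uM (a higher number here means more inhibition of growth at the concentration tested, a lower number less inhibition of growth), compound 1 gives "not active" (no number reported), so no single number stands for it. Compound 3 likewise gives "not active" (no number reported) in this assay, while compound 2 gives 22% there. Within the data shown here, none of these three pairs differs in only one place, so no single-change step is known, and compound 1 is simply one of two compounds without a number.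

Compound 4 `COc1cc(/C=C/C(=O)/C=C/c2ccco2)ccc1OCc1cn(CCCOc2cc(=O)oc3ccccc23)nn1` differs from compound 1 by furan-2-yl in place of phenyl on a double-bonded chain carbon bound to a double-bonded chain carbon. With compound 1 showing no measurable inhibition, the step to compound 4 in this assay is expected to be small, most likely none beyond the usual scatter, with at best a modest rise. Compound 4 is therefore estimated at 12%, in a range from 0% to 30%.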

Compound 4, percent growth inhibition at one concentration: "not active" (no number reported)
The entry for compound 4 holds no number; no gap can be computed for the estimate.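

In this assay, among these compounds, compound 4 gives "not active" (no number reported) and compound 1 gives "not active" (no number reported) so no step between these two compounds can be read. The compounds shown leave open whether furan-2-yl in place of phenyl alters growth inhibition at all. No evidence on hand bears on this result.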